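A few compounds are considered here, and "the series" means these few. Any claim that something is new, unique, unknown or untested is made for them only; others in the source may bear on it.

Compound 1 `COc1ccc(N(C)c2ncnc3occ(C)c23)cc1`: 80 nM
Compound 2 `CCCN(c1ccc(OC)cc1)c1ncnc2occ(C)c12`: 301 nM
Compound 3 `CSc1ccc(N(C)c2ncnc3occ(C)c23)cc1`: 520 nM

In a functional assay on Chorioallantoic membrane (Gallus gallus, strain Leghorn), read by microscopy, with a stated time of 40 h (on this read-out higher numbers stand for weaker inhibition and lower numbers for stronger inhibition), compound 1 stands lowest of the three numbers, at 80 nM. Compound 4 `Cc1coc2ncnc(N(C)c3ccc(N(C)C)cc3)c12` has not yet been measured. It carries dimethylamino in place of methoxy on an aromatic carbon. The one measured replacement of methoxy, methylsulfanyl in place of methoxy on an aromatic carbon, gave a 6.5-fold higher number from compound 1 to compound 3 (0.81 log units; beyond the scatter), a modest step beyond the scatter. The other measured step, a 3.8-fold higher number from compound 1 to compound 2 (0.58 log units; beyond the scatter), lies elsewhere in the structure and bears on this change only loosely. A modest step toward a higher number is therefore expected, estimated as a 3.1-fold higher number from compound 1 to compound 4 (0.49 log units; beyond the scatter). The estimated value for compound 4 is 250 nM, with an expected range from 70 nM to 900 nM.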

Compound 4, half-maximal inhibitory concentration: 653 nM
For compound 4 the middle estimate is 2.6-fold (0.42 log units) below the measured one; the measured number falls inside the stated range.
By their numbers in this assay, from the lowest: compound 1; then compounds 2, 3 and 4 (each within the scatter of the next, the first and the last beyond it).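

In this assay, a second replacement of methoxy on this aromatic carbon, para to a large group, also raises the number, with dimethylamino giving an 8.2-fold higher number from compound 1 to compound 4 (0.91 log units; beyond the scatter) in the same direction as methylsulfanyl. Dimethylamino and methylsulfanyl are not separated at this place, with a 1.3-fold higher number from compound 3 to compound 4 (0.10 log units; within the scatter) between them. No measurement at hand explains why methoxy differs from these two groups. From the compounds shown here alone, whether an ethoxy, a hydroxyl or a fluorine here would stay close to compound 1 remains open. So does whether dimethylamino would give a similar step alongside the longer chain of compound 2.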